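Swapping the Amine on a Thiocarbonyl Across Two Cores

The compounds below may be only part of what the source reports. "The series", "measured", "known", "first", "only" and "open" are said of these compounds alone.

Compound 2 `CC(C)N(C(=S)SCc1oc2ccccc2c(=O)c1Cl)C(C)C` carries a diisopropylamino group on a thiocarbonyl carbon. In a functional assay on MCF7 cells (Homo sapiens) for antiproliferative activity, read by MTT assay, with a stated time of 72 h (on this read-out lower numbers stand for stronger inhibition and higher numbers for weaker inhibition), compound 2 gives only a limit of the assay, > 40000 nM, not a number. Compound 1 `O=c1c(Cl)c(CSC(=S)N2CCCCC2)oc2ccccc12` has the same core with piperidin-1-yl in its place, and in this assay compound 1 gives 1000 nM. The change piperidin-1-yl in place of diisopropylamino on a thiocarbonyl carbon thus produced an at least 40-fold lower number from compound 2 to compound 1 (1.60 log units; beyond the scatter), which is read against (the limit of > 40000 nM in this assay, at which 1 of the 3 values shown sits).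

Compound 3 `COc1ccc2oc(CSC(=S)N(C(C)C)C(C)C)cc(=O)c2c1` combines the diisopropylamino group with a different core; how the two cores differ is not broken down here. In this assay compound 3 gives only a limit, > 25000 nM, marked by the limit of > 25000 nM in this assay, at which 1 of the 3 values shown sits. Compound 4 `COc1ccc2oc(CSC(=S)N3CCCCC3)cc(=O)c2c1` is compound 3 with the same change made once more: piperidin-1-yl in place of diisopropylamino on a thiocarbonyl carbon.

As far as these compounds go, since compound 3 sits at a limit, the starting point for this step is unknown. The expectation for compound 4 is an at least 8.3-fold lower number from compound 3 to compound 4 (0.92 log units; beyond the scatter), resting on the earlier step of an at least 40-fold lower number from compound 2 to compound 1 (1.60 log units; beyond the scatter). Compound 4 is expected to give about 3000 nM, within 500 nM to 20000 nM.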

Compound 4, half-maximal inhibitory concentration: 10000 nM
For compound 4 the middle estimate is 3.3-fold (0.52 log units) below the measured one; measured number inside the range.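

In this assay, piperidin-1-yl in place of diisopropylamino on a thiocarbonyl carbon again gives a lower number on the second core, with an at least 2.5-fold lower number from compound 3 to compound 4 (0.39 log units; beyond the scatter), so the change points the same way on both cores shown. Compound 3 gives only a limit of the assay, not a number: the limit of > 25000 nM in this assay, at which 1 of the 4 values shown sits. The two steps therefore cannot be ranked by size, and two cores alone do not make a rule for any further core: the same change on two cores in this assay, an at least 40-fold lower number (1.60 log units; beyond the scatter) from compound 2 to compound 1 and an at least 2.5-fold lower number (0.39 log units; beyond the scatter) from compound 3 to compound 4; the limit leaves it open whether they differ.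

The compounds shown leave open whether other cyclic amines on the thiocarbonyl carbon, such as pyrrolidine or morpholine, would follow piperidin-1-yl on these two cores, or whether a smaller open-chain group such as dimethylamino would behave like diisopropylamino. They also leave open what each separate difference between the two cores contributes, since no pair shown changes only one part of the core.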